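Triazinone for Uracil Across Two Related Cores

This account rests on a few compounds, and the source may have more. Where it says the series, first, only, none or still open, it means among the compounds named here.

Compound 1 `Nc1ncn(C/C=C2\OC(=O)C(OCc3ccccc3)=C2OCc2ccccc2)c(=O)n1` in a functional assay on HeLa cells (Homo sapiens) for inhibition, read by MTT assay, with a stated time of 72 h (a higher number here means a weaker inhibitor, a lower number a stronger inhibitor), gives 5910 nM. Compound 2 `O=C1O/C(=C\Cn2c(=O)[nH]c(=O)[nH]c2=O)C(OCc2ccccc2)=C1OCc1ccccc1` is reported only as a limit of the assay, and in this assay compound 2 gives > 100000 nM. The two differ by one change, (a group of 8 heavy atoms (3 carbon, 4 nitrogen, 1 oxygen; one six-membered aromatic ring with 3 hetero atoms) in place of a group of 9 heavy atoms (3 carbon, 3 nitrogen, 3 oxygen; one six-membered aromatic ring with 3 hetero atoms), on a saturated chain carbon bound to a double-bonded chain carbon), and the step of an at least 16-fold lower number from compound 2 to compound 1 (1.22 log units; beyond the scatter). Compound 3 `O=C1O[C@H]([C@@H](O)Cn2c(=O)[nH]c(=O)[nH]c2=O)C(OCc2ccccc2)=C1OCc1ccccc1` is likewise reported only as a limit, and in this assay compound 3 gives > 100000 nM. Two of the three measured values thus sit at the limit of > 100000 nM in this assay, at which 2 of the 3 values shown sit. The difference between the core of compound 2 and the core of compound 3 is not broken down here.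

Compound 4 `Nc1ncn(C[C@H](O)[C@H]2OC(=O)C(OCc3ccccc3)=C2OCc2ccccc2)c(=O)n1` carries the same kind of change relative to compound 3, (a group of 8 heavy atoms (3 carbon, 4 nitrogen, 1 oxygen; one six-membered aromatic ring with 3 hetero atoms) in place of a group of 9 heavy atoms (3 carbon, 3 nitrogen, 3 oxygen; one six-membered aromatic ring with 3 hetero atoms), on a saturated chain carbon, two bonds along the chain from an oxygen on a saturated carbon and a saturated ring carbon); the surroundings differ, since in compound 1 the group sits on a saturated chain carbon bound to a double-bonded chain carbon, whereas in compound 4 it sits on a saturated chain carbon, two bonds along the chain from an oxygen on a saturated carbon and a saturated ring carbon. Because compound 2 moved to compound 1 by an at least 16-fold lower number from compound 2 to compound 1 (1.22 log units; beyond the scatter), a step of roughly an at least 5.0-fold lower number from compound 3 to compound 4 (0.69 log units; beyond the scatter) is expected for compound 4 in this assay. The estimate for compound 4 is 20000 nM, expected between 3000 nM and 100000 nM.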

Compound 4, half-maximal inhibitory concentration: > 100000 nM
Compound 4: no number, only a limit; the forecaster's own chance of this, stated with the estimate: 35%; middle value at least 5.0-fold (0.69 log units) from the limit.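

Compound 4 is reported in this assay only as a limit, > 100000 nM. Compound 3 is likewise only a limit, and no step can be read between compound 3 and compound 4. The compounds shown leave open how far this change moves the number on the core of compound 3, with the readings held at: the limit of > 100000 nM in this assay, at which 3 of the 4 values shown sit.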